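Benzyl in Place of the Dimethylaminophenyl Sulfonamide Cap

This account rests on a few compounds, and the source may have more. Where it says the series, first, only, none or still open, it means among the compounds named here.

Measured compounds:
- compound 1, `CN(C)c1ccc(S(=O)(=O)N[C@H]2C3CC[C@H](C3)[C@@H]2C/C=C\CCCC(=O)O)cc1`: 7100 nM
- compound 2, `O=C(O)CCC/C=C\C[C@H]1[C@@H]2CCC(C2)[C@@H]1NC(=O)c1ccccc1`: > 800000 nM

Both compounds were tested in a functional assay (plasma) for inhibition, with Oryctolagus cuniculus as the target; a higher number here means a weaker inhibitor, a lower number a stronger inhibitor. Compound 1, with its dimethylaminophenyl sulfonamide on the shared core, gives 7100 nM in this assay. For compound 2, which carries a benzamide instead of a sulfonamide, the assay reached only a limit, > 800000 nM; this is the limit of > 800000 nM in this assay, at which 1 of the 2 values shown sits, not a measured number. For the measured compounds named here, compound 1 therefore holds the only real number here, and the benzamide compound 2 falls outside the measurable window.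

Compound 3, `O=C(O)CCC/C=C\C[C@H]1[C@@H]2CCC(C2)[C@@H]1NS(=O)(=O)Cc1ccccc1`, keeps the sulfonamide but changes the group on its sulfur: benzyl in place of 4-(dimethylamino)phenyl on a sulfonyl sulfur. Going by the values given here, no measured step between two compounds covers this kind of change, so the expectation rests on compound 1 alone. A loss of potency beyond the usual scatter is expected, since the aromatic ring is pushed one carbon away from the sulfonyl sulfur and the dimethylamino group is gone. The expected step of a 4.2-fold higher number from compound 1 to compound 3 (0.63 log units; beyond the scatter) is toward weaker inhibition. Compound 3 is estimated to give 30000 nM in this assay, within a range from 6000 nM to 200000 nM.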

Compound 3, half-maximal inhibitory concentration: 113000 nM
Beside the measured number, compound 3's estimate is 3.8-fold (0.58 log units) below it; low and high end bracket the measured number.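

With the sulfonamide kept, benzyl in place of 4-(dimethylamino)phenyl on a sulfonyl sulfur gives in this assay a 16-fold higher number from compound 1 to compound 3 (1.20 log units; beyond the scatter). The group on the sulfonyl sulfur can therefore shift inhibition by a large amount on its own, even with the rest of the molecule unchanged, which compound 1 alone could not show. Even so, compound 3 gives a real number, 113000 nM, so this weaker sulfonamide can still be read in this assay. The entry of the benzamide compound 2 is a limit and not a number: the limit of > 800000 nM in this assay, at which 1 of the 3 values shown sits.

The swap changes two things at once, as the dimethylamino group is lost and the ring is attached through an added carbon, so the compounds shown cannot say which of the two accounts for the step. A plain phenyl on the sulfonyl sulfur would separate these two changes, and a 2-phenylethyl group or a 4-methoxyphenyl group would show how far this position tolerates a longer chain or a different group on the ring.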